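The compounds below may be only part of what the source reports. "The series", "measured", "known", "first", "only" and "open" are said of these compounds alone.

Compound 1 `CC(CSc1nnc(-c2ccncc2)s1)C(=O)Nc1ccc(Cl)cc1` is measured in an ADME assay on HepG2 cells (Homo sapiens) for cytotoxicity, with a stated time of 3 days; on this read-out higher numbers stand for lower toxicity in this test and lower numbers for higher toxicity in this test; in this assay compound 1 gives > 50000 nM, a limit of the assay.
Compound 2 `CC(CSc1nnc(-c2ccncc2)s1)C(=O)Nc1ccc(Cl)cc1Cl` is measured in this assay too; in this assay compound 2 gives > 50000 nM, also a limit.
Compound 3 `O=C(CSc1nnc(-c2ccncc2)s1)Nc1c(Cl)cccc1Cl` has no reported result in this assay; for compound 3 the entry reads "not determined" (no result reported).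

The account concerns three measured compounds and one that is not yet measured. Compound 1 and compound 2 share a core and differ by hydrogen in place of chloro on an aromatic carbon. The step that the two limits leave unreadable from compound 2 to compound 1 is one that the two limits leave unreadable. How the core of compound 3 differs from that of compound 2 is not broken down here.

Compound 4 `O=C(CSc1nnc(-c2ccncc2)s1)Nc1ccccc1Cl` is to be measured in this assay. It differs from compound 3 by hydrogen in place of chloro on an aromatic carbon, the same change as that from compound 2 to compound 1, and its surroundings read the same word for word in both cases. Since compound 3 has no value, no step can be read from it. What can be said rests on (the limit of > 50000 nM in this assay, at which 2 of the 3 values shown sit), where compound 1 and compound 2 both sit. Compound 4 is therefore expected to land at 80000 nM, most likely reported again only as a limit, with a range of 30000 nM to 300000 nM.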

Compound 4, half-maximal cytotoxic concentration: > 50000 nM
Compound 4 ended at the assay's limit; the forecaster's own chance of this, stated with the estimate: 85%; the middle value does not contradict the limit.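

No new step can be read between compound 3 and compound 4: compound 3 has no reported result in this assay. Compound 4 gives > 50000 nM, which is a limit of the assay and not a number. The compounds shown leave open whether hydrogen in place of chloro changes this read-out at all.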